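Trifluoromethoxy for fluoro on the benzylidene ring

A few compounds are considered here, and "the series" means these few. Any claim that something is new, unique, unknown or untested is made for them only; others in the source may bear on it.

Measured compounds:
compound 1, `O=C1/C(=C/c2cccc(C(F)(F)F)c2)CCc2c(O)cccc21`, 1970 nM
compound 2, `O=C1/C(=C/c2cccc(F)c2)CCc2cc(O)ccc21`, 1230 nM

In a functional assay on RAW264.7 cells (Mus musculus) for inhibition (a lower number here means a stronger inhibitor, a higher number a weaker inhibitor), compound 1 gives 1970 nM. In this assay compound 2 gives 1230 nM. Within the data shown here, the two structures differ in more than one place, so no single step connects them; their two numbers lie within the usual scatter of each other, and compound 2 does not stand apart from compound 1 on what has been measured.

Compound 3, `O=C1/C(=C/c2cccc(OC(F)(F)F)c2)CCc2cc(O)ccc21`, is not yet measured in this assay. The change from compound 2 is trifluoromethoxy in place of fluoro on an aromatic carbon. Among the measured compounds shown here, nothing measured tells how this exchange moves the read-out, since the only other compound bears a different group on that ring and a shifted hydroxyl on the core. The number for compound 3 is therefore expected to stay close to that of compound 2, with a 1.2-fold higher number from compound 2 to compound 3 (0.09 log units; within the scatter) as the expected step, no further than the scatter in either direction. For compound 3 in this assay the estimate is 1500 nM, within 600 nM to 4000 nM.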

Compound 3, half-maximal inhibitory concentration: 520 nM
Beside the measured number, compound 3's estimate is 2.9-fold (0.46 log units) above it; the measured number lies below the stated range.
By their numbers in this assay, from the lowest: compound 3; then compounds 2 and 1 (each within the scatter of the next).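

In this assay, trifluoromethoxy in place of fluoro on an aromatic carbon, meta to a large group, gives a 2.4-fold lower number from compound 2 to compound 3 (0.37 log units; beyond the scatter), a modest step. Among these compounds, this is the first comparison that differs in one place only, and it shows that the read-out responds to the group at this position, which the earlier pair of compounds, differing in more than one place, could not show; the exchange adds heavy atoms and a hydrogen-bond acceptor, and the number does not rise. No measurement at hand bears on what lies behind this step, so it stands as an observation from a single pair of compounds.

A single exchange leaves open whether the step follows the oxygen, the fluorines or the overall size of the entering group, and a methoxy group or an ethoxy chain at the same position on the core of compound 2 would help to separate these. Also open, on these data alone, is whether the same exchange would read the same way with the hydroxyl placed as in compound 1, and whether an amine at this position would be accepted at all.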